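Chloro for Fluoro on the Butyl Compound

A few compounds are considered here, and "the series" means these few. Any claim that something is new, unique, unknown or untested is made for them only; others in the source may bear on it.

In a functional assay on the whole organism for inhibition, with Mythimna separata as the target, with a stated time of 5 days (on this read-out higher numbers stand for an effect only at larger amounts of compound and lower numbers for an effect already at smaller amounts), compound 1 (`CCCCn1ncc(OCc2nnc(-c3ccc(F)cc3)o2)c(Cl)c1=O`) gives 162 ug/mL as the higher of the two actual numbers in this small set. The nearest is compound 3 (`CC(C)(C)n1ncc(OCc2nnc(-c3ccc(F)cc3)o2)c(Cl)c1=O`) at 5.2 ug/mL on the same read-out. Compound 2 (`CCn1ncc(OCc2nnc(-c3ccc(F)cc3)o2)c(Cl)c1=O`) reads > 300 ug/mL as a limit of the assay and not a number.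

Compound 4 (`CCCCn1ncc(OCc2nnc(-c3ccc(Cl)cc3)o2)c(Cl)c1=O`) differs from compound 1 in a single place: chloro in place of fluoro on an aromatic carbon with chloro in place of fluoro on an aromatic carbon, para to a large group, which turns 4-fluorophenyl into 4-chlorophenyl.

Every measured step lies elsewhere, in the group on the aromatic nitrogen. They run a 31-fold lower number from compound 1 to compound 3 (1.49 log units; beyond the scatter) and an at least 57-fold lower number from compound 2 to compound 3 (1.76 log units; beyond the scatter) and an at least 1.8-fold higher number from compound 1 to compound 2 (0.26 log units; that floor lies within the scatter) in turn, the first two of them large. None of them changes the 4-fluorophenyl, so they give no size for this swap. In this assay compound 1 stands at 162 ug/mL, and this change is therefore expected to stay within the scatter of that value. The expected move is a 1.1-fold lower number from compound 1 to compound 4 (0.03 log units; within the scatter) by this estimate. Compound 4 is estimated at 150 ug/mL with an expected range of 60 ug/mL to 350 ug/mL on this read-out.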

Compound 4, half-maximal effective concentration: 224 ug/mL
The estimate for compound 4 lay 1.5-fold (0.17 log units) below the measured number; measured number inside the range.
By their numbers in this assay, from the lowest: compound 3; then compounds 1 and 4 (each within the scatter of the next). At a limit, above all of these: compound 2.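

In this assay, the change from 4-fluorophenyl to 4-chlorophenyl on the butyl compound comes to a 1.4-fold higher number from compound 1 to compound 4 (0.14 log units; within the scatter), so compounds 1 and 4 cannot be told apart on this read-out. Among these compounds, this is the first look at the aromatic carbon para to a large group, since all the earlier steps lay in the group on the aromatic nitrogen, and it shows that, with butyl on that nitrogen, fluoro and chloro at this place give values within the scatter of each other. Compound 2 alone sits at a limit of the assay and not at a number, so neither end of this step is cut off by it: the limit of > 300 ug/mL in this assay, at which 1 of the 4 values shown sits.

The compounds shown leave open whether the same swap would also make so little difference with tert-butyl on the aromatic nitrogen, where compound 3 gives 5.2 ug/mL. They also leave open what this ring position would tolerate beyond these two halogens, since a methoxy group, a nitrile, an amine or a carboxylic acid in place of the fluoro would test it far more widely.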